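This account rests on a few compounds, and the source may have more. Where it says the series, first, only, none or still open, it means among the compounds named here.

Of the compounds shown here, two have been measured in a functional assay on A549 cells (Homo sapiens) for antiproliferative activity, read by MTT assay, with a stated time of 24 h; on this read-out higher numbers stand for weaker inhibition and lower numbers for stronger inhibition. Compound 1 `COc1ccc(-c2cc(/C=C/C(=O)c3ccc(OC)c(OC)c3)nc3cc(-c4ccccc4)nn23)cc1` carries a 3,4-dimethoxyphenyl on its carbonyl carbon, and in this assay compound 1 gives 7400 nM. Compound 2 `COc1ccc(-c2cc(/C=C/C(=O)c3ccc(C)c(C)c3)nc3cc(-c4ccccc4)nn23)cc1OC` carries a 3,4-dimethylphenyl at that carbonyl, and in this assay compound 2 gives 9300 nM. The two numbers lie within the usual scatter of each other, so neither compound can be set apart from the other on this read-out. Compound 3 `COc1ccc(C(=O)/C=C/c2cc(-c3ccc(OC)c(OC)c3)n3nc(-c4ccccc4)cc3n2)cc1OC` is not yet measured. It differs from compound 2 in one place: 3,4-dimethoxyphenyl in place of 3,4-dimethylphenyl on a carbonyl carbon. The pair of compound 1 and compound 2 does not isolate this change, since they also differ elsewhere, so it gives only loose guidance. Given that neither measured value separates from the other, the step from compound 2 to compound 3 is expected to be small, a 1.2-fold lower number from compound 2 to compound 3 (0.09 log units; within the scatter), in no clear direction beyond the scatter. Compound 3 is accordingly estimated at 7500 nM, with a range from 3500 nM to 16000 nM.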

Compound 3, half-maximal inhibitory concentration: 3900 nM
Compound 3: middle estimate off by 1.9-fold (0.28 log units), on the high side, and the stated range covers the measured number.
By their numbers in this assay, from the lowest: compounds 3, 1 and 2 (each within the scatter of the next, the first and the last beyond it).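

In this assay, among these compounds, the change from 3,4-dimethylphenyl to 3,4-dimethoxyphenyl on the carbonyl carbon gives a 2.4-fold lower number from compound 2 to compound 3 (0.38 log units; beyond the scatter) and is the first single-place change to clear the scatter, so this position does respond to its aryl group, though only modestly. Methoxy in place of hydrogen on an aromatic carbon gives a 1.9-fold lower number from compound 1 to compound 3 (0.28 log units; within the scatter) and cannot be separated from no change on this read-out. Nothing available here explains either step.

Among the compounds shown here, only one pair isolates the carbonyl position, so it remains open whether both methoxy groups of 3,4-dimethoxyphenyl are needed for the lower number. An unsubstituted phenyl, a 4-methoxyphenyl or a 3,4-dihydroxyphenyl on the same carbonyl carbon would each address that question.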